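This account rests on a few compounds, and the source may have more. Where it says the series, first, only, none or still open, it means among the compounds named here.

Measured in a functional assay on Fem-X cells (Homo sapiens) for cytotoxicity, read by MTT assay, with a stated time of 72 h; a lower number here means a stronger inhibitor, a higher number a weaker inhibitor:
- compound 1 `CC(C)(C)C1=CC(=O)C=C(NCC(=O)O)C1=O`: 34300 nM
- compound 2 `CC(C)C[C@H](NC1=CC(=O)C=C(C(C)(C)C)C1=O)C(=O)O`: 39400 nM
- compound 3 `C[C@H](NC1=CC(=O)C=C(C(C)(C)C)C1=O)C(=O)O`: 20100 nM

At 20100 nM, compound 3 lies within the usual scatter of both other compounds, so the three values set no firm order. Compound 4 `CSCC[C@H](NC1=CC(=O)C=C(C(C)(C)C)C1=O)C(=O)O` departs from compound 3 by this change: (methylsulfanyl)methyl in place of hydrogen on a saturated chain carbon, two bonds along the chain from an amine nitrogen and a carbonyl carbon. It places (methylsulfanyl)methyl in place of hydrogen on a saturated chain carbon, two bonds along the chain from an amine nitrogen and a carbonyl carbon.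

Three measured steps at the same chain carbon bear on this: a 1.7-fold lower number from compound 1 to compound 3 (0.23 log units; within the scatter), a 1.1-fold higher number from compound 1 to compound 2 (0.06 log units; within the scatter) and a 2.0-fold lower number from compound 2 to compound 3 (0.29 log units; within the scatter). All three stay within the scatter. The nearest guide is compound 2, whose isobutyl-bearing chain gives 39400 nM. No step beyond the scatter is therefore expected in this assay, and any drift would be toward a slightly higher number. The expected step is a 1.4-fold higher number from compound 3 to compound 4 (0.14 log units; within the scatter). For compound 4 the estimated value is 28000 nM, with an expected range of 14000 nM to 55000 nM.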

Compound 4, half-maximal inhibitory concentration: 34800 nM
Estimate against measurement, compound 4: 1.2-fold (0.09 log units) below; the range from low to high includes it.
By their numbers in this assay, from the lowest: compounds 3, 1, 4 and 2 (each within the scatter of the next).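

Placing (methylsulfanyl)methyl on this saturated chain carbon brings sulfur into the series, and in this assay the change stays within the scatter (a 1.7-fold higher number from compound 3 to compound 4 (0.24 log units; within the scatter)). The exchange of isopropyl for (methylsulfanyl)methyl also stays within the scatter (a 1.1-fold lower number from compound 2 to compound 4 (0.05 log units; within the scatter)), as does 2-(methylsulfanyl)ethyl in place of hydrogen (a 1.0-fold higher number from compound 1 to compound 4 (0.01 log units; within the scatter)). With this sulfur-bearing chain the four compounds still show no firm order at this position, and nothing measured on them speaks to why.

Going by these compounds, whether an amine, a hydroxyl group or a phenyl ring on this chain carbon would move the number beyond the scatter stays open. On these data alone, the carboxylic acid is common to all four compounds, so the effect of an ester or an amide in its place is also open.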